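A Second Methyl on the Aryl Ketone of Compound 3

This account rests on a few compounds, and the source may have more. Where it says the series, first, only, none or still open, it means among the compounds named here.

Measured compounds:
compound 1 `O=C(/C=C/c1ccc2c(c1)B(O)OC2)c1ccc(-c2ccccc2)cc1` — 4900 nM
compound 2 `O=C(/C=C/c1ccc2c(c1)B(O)OC2)c1cccs1` — 10400 nM
compound 3 `Cc1ccc(C(=O)/C=C/c2ccc3c(c2)B(O)OC3)cc1` — 3700 nM

In a functional assay on SK-OV-3 cells (Homo sapiens) for cytotoxicity, read by MTT assay, with a stated time of 48 h (on this read-out higher numbers stand for weaker inhibition and lower numbers for stronger inhibition), compound 3 gives the lowest of the three numbers. Its nearest neighbour is compound 1, and the step of a 1.3-fold lower number from compound 1 to compound 3 (0.12 log units; within the scatter) lies within the scatter, so the two cannot be ordered. The step of a 2.8-fold lower number from compound 2 to compound 3 (0.45 log units; beyond the scatter) is beyond the scatter and modest in size.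

Compound 4 `Cc1ccc(C(=O)/C=C/c2ccc3c(c2)B(O)OC3)cc1C` differs from compound 3 in one place: methyl in place of hydrogen on an aromatic carbon. For the measured compounds named here, only the step of a 1.3-fold lower number from compound 1 to compound 3 (0.12 log units; within the scatter) touches the same ring, and it concerns a swap of one group for another rather than the addition of a methyl to a hydrogen; it was small. Going by the values given here, no measured pair shows what a second methyl on this ring does. The step from compound 3 to compound 4 in this assay is therefore expected to be small, a 1.1-fold lower number from compound 3 to compound 4 (0.02 log units; within the scatter), with no clear direction beyond the scatter.

Compound 4 is expected to give 3500 nM, with a range from 1500 nM to 8500 nM.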

Compound 4, half-maximal inhibitory concentration: 1900 nM
Beside the measured number, compound 4's estimate is 1.8-fold (0.27 log units) above it, and the stated range covers the measured number.
By their numbers in this assay, from the lowest: compounds 4, 3 and 1 (each within the scatter of the next, the first and the last beyond it); then compound 2.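

For the compounds shown here, this is the first measured step in the set that adds a methyl in place of hydrogen on this aromatic ring, at a carbon ortho to a methyl group and meta to a large group. In this assay, the result is a 1.9-fold lower number from compound 3 to compound 4 (0.29 log units; within the scatter), so the two compounds cannot be ordered and the added methyl produces no change that can be told apart from the usual scatter. No evidence in hand bears on why this methyl leaves the number within that scatter.

The compounds shown leave open how an amine, a methoxy group, a chlorine or a longer chain such as ethyl would read at this same carbon. They also leave open whether a methyl at this position would give a similar step on the ketones carrying a biphenyl-type or thiophen-2-yl group.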